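This account rests on a few compounds, and the source may have more. Where it says the series, first, only, none or still open, it means among the compounds named here.

Measured compounds:

Compound 1, `NC[C@@H]1CCCc2cc(S(=O)(=O)c3cc[nH]c3)ccc21`, gives 0.316 nM in an assay on isolated protein for displacement of a labelled ligand from 5-hydroxytryptamine receptor 6 (Homo sapiens); a higher number here means a weaker inhibitor, a lower number a stronger inhibitor.
Compound 2, `CNC[C@@H]1CCCc2cc(S(=O)(=O)c3cc[nH]c3)ccc21`, gives 0.159 nM in this assay.
Compound 3, `NC(=O)CNC[C@@H]1CCCc2cc(S(=O)(=O)c3cccc(F)c3)ccc21`, gives 0.1 nM in this assay.

Among the compounds with values here, the one change that is seen twice here is methyl in place of hydrogen on an amine nitrogen. From compound 1 to compound 2 it is already measured: a 2.0-fold lower number from compound 1 to compound 2 (0.30 log units; within the scatter), so compound 1 and compound 2 cannot be told apart on this evidence. Compound 3 has a different core, and the difference between the two cores is not broken down here; its value stands within the scatter of compound 2 and beyond it only against compound 1.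

Compound 4, `CN(CC(N)=O)C[C@@H]1CCCc2cc(S(=O)(=O)c3cccc(F)c3)ccc21`, has not yet been measured. It carries the same kind of change as was made on compound 1, namely (methyl in place of hydrogen on an amine nitrogen), but the place is not identical: on compound 1 the amine nitrogen had one saturated chain carbon beside it, on compound 3 it has two. The expectation rests on one observation only, the step of a 2.0-fold lower number from compound 1 to compound 2 (0.30 log units; within the scatter), which lay within the scatter. Within the data shown here, on that basis the step from compound 3 to compound 4 is expected to be small, a 1.3-fold lower number from compound 3 to compound 4 (0.10 log units; within the scatter), with a wide band because only one comparison supports it. Compound 4 is therefore estimated at 0.08 nM, between 0.03 nM and 0.25 nM.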

Compound 4, inhibition constant: 1.26 nM
The estimate for compound 4 lay 16-fold (1.20 log units) below the measured number; the whole stated range lies below it.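

In this assay, methyl in place of hydrogen on an amine nitrogen gives a 13-fold higher number from compound 3 to compound 4 (1.10 log units; beyond the scatter), a large loss set against a small step on the other core, so this change did not carry over from one core to the other in this series: the same change on two cores in this assay, a 2.0-fold lower number (0.30 log units; within the scatter) from compound 1 to compound 2 and a 13-fold higher number (1.10 log units; beyond the scatter) from compound 3 to compound 4, 25-fold (1.40 log units) apart, beyond the scatter of two such steps The step from compound 1 to compound 2 therefore gives no safe guide to the same change on the core of compound 3, and a single pair on each core cannot show how the step behaves on either core more generally. It also does not show which difference between the pairs matters, since the amine nitrogen of compound 3 carries a carbamoylmethyl group, that of compound 1 carries none, and the rest of the two cores differs as well.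

Still open, on these data alone, is what the same methyl step does when carbamoylmethyl sits on the amine nitrogen of the core of compound 1, which would separate the effect of that group from the effect of the rest of the core. Also open, as far as these compounds go, is whether a plain ethyl group, a longer chain or a carboxylic acid in place of the amide would leave the step as large as it is from compound 3 to compound 4.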